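Pyridinyl Hydrazone Replacing the Pyrazolyl Group

The compounds below may be only part of what the source reports. "The series", "measured", "known", "first", "only" and "open" are said of these compounds alone.

The compounds share one core bearing a hydrazone. Compound 1 `NS(=O)(=O)c1ccc(Nc2nc(N/N=C/c3ccc(C(F)(F)F)cc3)nc(Nc3ccccc3)n2)cc1` carries 4-(trifluoromethyl)phenyl on the carbon with a double bond to nitrogen, and in a functional assay on NCI-H322M cells (Homo sapiens) for inhibition, read by sulforhodamine B assay, with a stated time of 48 h (a higher number here means that more compound is tolerated, a lower number that less compound is tolerated), compound 1 gives 36100 nM. Compound 2 `Cc1nn(-c2ccccc2)cc1/C=N/Nc1nc(Nc2ccccc2)nc(Nc2ccc(S(N)(=O)=O)cc2)n1` carries 3-methyl-1-phenyl-1H-pyrazol-4-yl at that carbon. For compound 2 this assay reports only a limit, > 100000 nM, so compound 2 stands at the top of the numbers shown without an exact value. Within the data shown here, the one measured step, an at least 2.7-fold higher number from compound 1 to compound 2 (0.44 log units; beyond the scatter), is bounded on one side only because of the limit of > 100000 nM in this assay, at which 1 of the 2 values shown sits.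

Compound 3 `NS(=O)(=O)c1ccc(Nc2nc(N/N=C/c3ccccn3)nc(Nc3ccccc3)n2)cc1` is not yet measured: pyridin-2-yl in place of 3-methyl-1-phenyl-1H-pyrazol-4-yl on a carbon with a double bond to nitrogen. Among the measured compounds shown here, no measured step covers pyridin-2-yl at this carbon, so the only step bearing on the change is the one from compound 1 to compound 2 at the same position, which raised the number beyond the scatter. The entering group is a single six-membered aromatic ring, as is the 4-(trifluoromethyl)phenyl of compound 1, so the number is expected to move back toward the value of compound 1 rather than rise further. Compound 3 is therefore estimated at 60000 nM (range 20000 nM to 200000 nM), an expected step of an at least 1.6-fold lower number from compound 2 to compound 3 (0.22 log units; that floor lies within the scatter), though the measurement may again end at the limit.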

Compound 3, concentration lethal to 50% of the cells: > 100000 nM
Compound 3: no number, only a limit; the forecaster's own chance of this, stated with the estimate: 40%; middle value at least 1.6-fold (0.22 log units) from the limit.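

With pyridin-2-yl on the carbon with a double bond to nitrogen, this assay shows an at least 2.7-fold higher number from compound 1 to compound 3 (0.44 log units; beyond the scatter), so the rise seen with 3-methyl-1-phenyl-1H-pyrazol-4-yl does not require that group's two rings: a single six-membered aromatic ring can also give a higher number than 4-(trifluoromethyl)phenyl does. In this assay compound 3 gives > 100000 nM, which is a limit and not a number. The step from compound 2 to compound 3 cannot be read, so the two entering groups cannot be ranked against each other, because both compounds end at the same limit: the limit of > 100000 nM in this assay, at which 2 of the 3 values shown sit.

The compounds shown leave open whether the ring nitrogen of pyridin-2-yl plays any part, since an unsubstituted phenyl, pyridin-3-yl and pyridin-4-yl do not appear among them at this carbon. They also leave open whether 4-(trifluoromethyl)phenyl owes its lower number to the trifluoromethyl group, which a comparison with a methyl group or a chlorine in its place could address.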